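Series notes: the step from compound 3 to compound 4

A few compounds are considered here, and "the series" means these few. Any claim that something is new, unique, unknown or untested is made for them only; others in the source may bear on it.

The three measured compounds share one core and differ only in the group on an aromatic carbon ortho to a fused ring. Compound 1 `CCOC(=O)C(C)Nc1cccc2c(S(=O)(=O)Nc3onc(C)c3C)cccc12` in an assay on VSM-A10 cells for antagonist activity at Endothelin-1 receptor (Rattus norvegicus) (a lower number here means a stronger inhibitor, a higher number a weaker inhibitor), gives 400 nM. Compound 2 `Cc1noc(NS(=O)(=O)c2cccc3c(N4CCCCC4=O)cccc23)c1C` gives 270 nM in this assay, and compound 3 `Cc1noc(NS(=O)(=O)c2cccc3c(NCc4ccccc4)cccc23)c1C` gives 590 nM. Compound 3 thus carries the highest number of the three: the step of a 1.5-fold higher number from compound 1 to compound 3 (0.17 log units; within the scatter) stays within the scatter, while the step of a 2.2-fold higher number from compound 2 to compound 3 (0.34 log units; beyond the scatter) is modest but beyond it. Across (1-(ethoxycarbonyl)ethyl)amino, 2-oxopiperidin-1-yl and benzylamino, the numbers stay in a narrow band.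

Compound 4 `Cc1noc(NS(=O)(=O)c2cccc3c(CN(C)C)cccc23)c1C` is not yet measured. It differs from compound 3 by (dimethylamino)methyl in place of benzylamino on an aromatic carbon. The two steps that end at compound 3 bear on this change, since each also swaps the whole group on that carbon; they show this position accepting varied groups with at most a modest shift. Going by the values given here, a group with no ring and no hydrogen-bond donor has no precedent among the measured compounds, so the expectation in this assay is a step of about a 1.0-fold higher number from compound 3 to compound 4 (0.01 log units; within the scatter), with no direction to be claimed beyond the scatter. Compound 4 is estimated at 600 nM, in a range from 180 nM to 2500 nM.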

Compound 4, half-maximal inhibitory concentration: 2800 nM
Compound 4: middle estimate off by 4.7-fold (0.67 log units), on the low side; the measured number lies above the stated range.
By their numbers in this assay, from the lowest: compounds 2, 1 and 3 (each within the scatter of the next, the first and the last beyond it); then compound 4.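

In this assay the position that had held three groups in a narrow band proves less forgiving of (dimethylamino)methyl, with a 4.7-fold higher number from compound 3 to compound 4 (0.68 log units; beyond the scatter) and a 7.0-fold higher number from compound 1 to compound 4 (0.85 log units; beyond the scatter) both beyond the scatter and a 10-fold higher number from compound 2 to compound 4 (1.02 log units; beyond the scatter) large, all in the same direction. The group on compound 1 also has no ring and the group on compound 2 has no hydrogen-bond donor, yet both give lower numbers, so neither feature alone tracks the rise; compound 4 stands apart among the four in lacking both and in joining its group to the aromatic carbon through carbon rather than nitrogen. No supporting measurement is available to explain this step.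

The compounds shown leave open whether the higher number follows the carbon link or the dimethylamino end, and dimethylamino placed directly on the aromatic carbon, or benzylaminomethyl, would separate the two. Also open, going by these compounds, is whether a longer chain between the aromatic carbon and the dimethylamino nitrogen, or a carboxylic acid at this position, would return the number to the earlier band.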